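Chloro to Trifluoromethyl on Two Related Cores

The source may report more compounds than this note shows. Statements on the series, on what has been measured and on what is new or still open speak of the compounds shown alone.

Measured compounds:
compound 1, `C/C(=N\NC(N)=S)c1ccc2[nH]c(-c3ccc(Cl)cc3)nc2c1`: 2000 nM
compound 2, `C/C(=N\NC(N)=S)c1ccc2[nH]c(-c3ccc(C(F)(F)F)cc3)nc2c1`: 2000 nM
compound 3, `CC(=O)c1ccc2c(c1)nc(-c1ccc(Cl)cc1)n2C1CCCCC1`: 58000 nM

The three measured compounds were tested in an ADME assay on MT4 cells (Homo sapiens) for cytotoxicity, read by MTT assay, with a stated time of 96 h; on this read-out higher numbers stand for lower toxicity in this test and lower numbers for higher toxicity in this test. Compound 1 and compound 2 share a core and differ only in trifluoromethyl in place of chloro on an aromatic carbon. In this assay compound 1 gives 2000 nM, and compound 2 gives 2000 nM; the step of no change at the digits printed from compound 1 to compound 2 (within the scatter).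

Compound 3 has a different core; the difference between the core of compound 1 and that of compound 3 is not broken down here. In this assay compound 3 gives 58000 nM, which stands beyond the scatter above the numbers of both compound 1 and compound 2.

The unmeasured compound 4, `CC(=O)c1ccc2c(c1)nc(-c1ccc(C(F)(F)F)cc1)n2C1CCCCC1`, is derived from compound 3 by trifluoromethyl in place of chloro on an aromatic carbon. This is the same change that connects compound 1 to compound 2, made on a different core, and the place of the change is described in the same words for both pairs.

The expectation for compound 4 rests on the measured pair: because the step of no change at the digits printed from compound 1 to compound 2 (within the scatter), the same change on the core of compound 3 is expected to leave the number essentially where it is. The estimated step for compound 4 is therefore no change at the digits printed from compound 3 to compound 4 (within the scatter). Compound 4 is thus expected to give about 58000 nM in this assay, with a plausible range from 25000 nM to 130000 nM, resting on the value of compound 3, 58000 nM.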

Compound 4, half-maximal cytotoxic concentration: 41000 nM
For compound 4 the middle estimate is 1.4-fold (0.15 log units) above the measured one, and the stated range covers the measured number.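

On the core of compound 3, trifluoromethyl in place of chloro on an aromatic carbon gives a 1.4-fold lower number from compound 3 to compound 4 (0.15 log units; within the scatter) in this assay. Set beside the earlier pair, the change carries from one core to the other with no difference that can be told apart: the same change on two cores in this assay, no change at the digits printed (within the scatter) from compound 1 to compound 2 and a 1.4-fold lower number (0.15 log units; within the scatter) from compound 3 to compound 4, 1.4-fold (0.15 log units) apart, within the scatter of two such steps This shows that on these two cores the exchange of chloro for trifluoromethyl leaves the number in this assay where it was, but it rests on only two pairs and does not show that the same would hold on any further core, in any other test, or why the number stays put.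

The compounds shown leave open whether other groups in the same place, para to a large group, such as a methoxy group, an amine, a nitrile or a carboxylic acid, would also leave the number unchanged on either core. They also leave open whether the agreement between the two steps would last on a third core, since a pair on one more core, carrying the same two groups, is not among the compounds shown here.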